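Trimming the amide from an alkynyl aryloxyacetic acid

The compounds below may be only part of what the source reports. "The series", "measured", "known", "first", "only" and "open" are said of these compounds alone.

Measured so far:
compound 1 `Cn1ccnc1C#Cc1cc(Cl)ccc1OCC(=O)O` 1470 nM
compound 2 `CN(C)C(=O)c1ccc(C#Cc2cc(Cl)ccc2OCC(=O)O)cc1` 55 nM

The two compounds were characterized in an assay on CHO cells for displacement of a labelled ligand from prostaglandin D2 receptor 2 (Homo sapiens), read by scintillation counting; on this read-out higher numbers stand for weaker inhibition and lower numbers for stronger inhibition. Compound 1 gave 1470 nM, whereas compound 2 gave 55 nM. Within the data shown here, compound 2 therefore stands lowest of the two numbers, and its gap to compound 1, the only neighbour, is beyond the scatter of repeated measurements.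

Compound 3 `O=C(O)COc1ccc(Cl)cc1C#Cc1ccccc1` has not yet been measured in this assay. It differs from compound 2 in one place: hydrogen in place of dimethylcarbamoyl on an aromatic carbon, on an aromatic carbon of a six-membered aromatic ring of carbon only.

Among the measured compounds shown here, no measured pair shows this change directly, so its size can only be estimated. Compound 3 is expected to give a number that is higher, meaning weaker, than compound 2, by a step of a 4.5-fold higher number from compound 2 to compound 3 (0.66 log units; beyond the scatter) in this assay. The estimate for compound 3 is 250 nM, within a range from 60 nM to 1000 nM.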

Compound 3, inhibition constant: 108 nM
Compound 3: middle estimate off by 2.3-fold (0.36 log units), on the high side; measured number inside the range.
By their numbers in this assay, from the lowest: compounds 2 and 3 (each within the scatter of the next); then compound 1.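

With hydrogen in place of dimethylcarbamoyl on the aromatic carbon para to a large group, this assay gives a 2.0-fold higher number from compound 2 to compound 3 (0.29 log units; within the scatter), so the number at this position holds without that amide and the two compounds cannot be told apart. With phenyl in place of 1-methyl-1H-imidazol-2-yl on a triple-bonded carbon, the step is a 14-fold lower number from compound 1 to compound 3 (1.13 log units; beyond the scatter), so among these compounds the large difference goes with the group on the triple-bonded carbon. Nothing at hand accounts for either step.

On these data alone, it remains open whether a methoxy group, a fluorine or a primary amine on that same aromatic carbon would move the number beyond the scatter from compound 3. Also open, as far as these compounds go, is how a pyridine ring or a thiophene ring on the triple-bonded carbon would compare with phenyl.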